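The source may hold more compounds than are shown below. What is called first, only, known or untested is meant among the compounds shown, and "the series" means these compounds.

Measured so far:
- compound 1, `CN(CC1CCN(CCCc2c[nH]c3ccc(-n4cnnc4)cc23)CC1)C(=O)Nc1ccccc1`: 6.2 nM
- compound 2, `CN(Cc1cccs1)C1CCN(CCCc2c[nH]c3ccc(-n4cnnc4)cc23)CC1`: 140 nM
- compound 3, `CC(=O)Nc1ccc([C@@H](C)NCC2CCN(CCCc3c[nH]c4ccc(-n5cnnc5)cc34)CC2)cc1`: 8.9 nM

All three come from an assay on CHO cells for displacement of a labelled ligand from 5-hydroxytryptamine receptor 1B (Homo sapiens); on this read-out lower numbers stand for stronger inhibition and higher numbers for weaker inhibition. Compound 3 has the second highest of the three numbers in this assay; its nearest neighbour is compound 1, a gap within the scatter, so no order between these two can be stated. Its furthest neighbour is compound 2, whose number is beyond the scatter higher, so compound 3 inhibits more strongly than compound 2.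

Compound 4, `c1ccc(NCC2CCN(CCCc3c[nH]c4ccc(-n5cnnc5)cc34)CC2)nc1`, differs from compound 3 in one place: pyridin-2-yl in place of 1-(4-acetamidophenyl)ethyl on an amine nitrogen. Going by the values given here, no measured pair shows this change, so its size cannot be read from the series. A modest weakening is expected, the step of a 2.2-fold higher number from compound 3 to compound 4 (0.35 log units; beyond the scatter) being the estimate, with the range wide. Compound 4 is expected at 20 nM, between 5 nM and 80 nM.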

Compound 4, half-maximal inhibitory concentration: 3.3 nM
Estimate against measurement, compound 4: 6.1-fold (0.78 log units) above; the measured number lies below the stated range.
By their numbers in this assay, from the lowest: compounds 4, 1 and 3 (each within the scatter of the next, the first and the last beyond it); then compound 2.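

In this assay the amine nitrogen does not need the 1-(4-acetamidophenyl)ethyl group and its defined stereocentre: pyridin-2-yl in its place gives a 2.7-fold lower number from compound 3 to compound 4 (0.43 log units; beyond the scatter) and so a much smaller substituent holds the binding. Against the other arms, (pyridin-2-yl)amino gives a 1.9-fold lower number from compound 1 to compound 4 (0.27 log units; within the scatter) and no loss from removing methyl(phenylcarbamoyl)amino, and it gives a 42-fold lower number from compound 2 to compound 4 (1.63 log units; beyond the scatter) against methyl((thiophen-2-yl)methyl)amino on a saturated ring carbon. Nothing available explains these steps. Still open, going by these compounds, is whether a plain phenyl or a methyl on that amine nitrogen would hold this level.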